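Replacing 1-benzofuran-2-yl with iodo in compound 3

This account rests on a few compounds, and the source may have more. Where it says the series, first, only, none or still open, it means among the compounds named here.

In a functional assay on HepG2 cells (Homo sapiens) for antiproliferative activity, read by XTT assay, with a stated time of 72 h (on this read-out higher numbers stand for weaker inhibition and lower numbers for stronger inhibition), compound 3 `Cc1ncnc2c1c(-c1cc3ccccc3o1)cn2[C@@H]1O[C@H](CO)[C@@H](O)[C@H]1O` gives > 20000 nM which is a limit and not a number. Compound 1 `COc1ncnc2c1c(-c1cc3ccccc3o1)cn2[C@@H]1O[C@H](CO)[C@@H](O)[C@H]1O` gives > 20000 nM which is also a limit. Compound 2 `Cc1ncnc2c1c(-c1cccs1)cn2[C@@H]1O[C@H](CO)[C@@H](O)[C@H]1O` gives > 15000 nM which is again a limit. None of these three compounds therefore has an actual number yet.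

Compound 4 `Cc1ncnc2c1c(I)cn2[C@@H]1O[C@H](CO)[C@@H](O)[C@H]1O` comes from compound 3 through a single change iodo in place of 1-benzofuran-2-yl on an aromatic carbon and shares the rest of its structure with compound 3. Among the compounds with values here, two measured steps bear on this. Within the data shown here, the closer one changes the group on that same carbon, with thiophen-2-yl and 1-benzofuran-2-yl joined by a step that the two limits leave unreadable from compound 2 to compound 3 as the only evidence. The other concerns methoxy and methyl, joined by a step that the two limits leave unreadable from compound 1 to compound 3 with no more to read from it. Neither gives a size to carry over, so any expectation here stays loose.

Iodo is also unlike the ring groups carried by compound 2 and compound 3, so a real number is possible, though another limit would be no surprise. The expected move is an at least 3.3-fold lower number from compound 3 to compound 4 (0.52 log units; beyond the scatter) in the direction of stronger inhibition. For compound 4 the estimate is 6000 nM with an expected range from 500 nM to 20000 nM around it.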

Compound 4, half-maximal inhibitory concentration: 3460 nM
Compound 4: middle estimate off by 1.7-fold (0.24 log units), on the high side, and the stated range covers the measured number.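

In this assay, within the data shown here, the steps among the earlier compounds cannot be read, but iodo on this aromatic carbon gives a measured number, with an at least 5.7-fold lower number from compound 3 to compound 4 (0.76 log units; beyond the scatter) and an at least 4.3-fold lower number from compound 2 to compound 4 (0.63 log units; beyond the scatter). This shows that the group on this carbon can change the read-out by more than the usual scatter, something the limits of the ring-bearing compounds could not show. On these data alone, both sizes are only floors, as compound 2 and compound 3 each carry a limit and not a number, so the full size of the change from thiophen-2-yl or 1-benzofuran-2-yl to iodo remains unknown.

The compounds shown leave open whether iodine itself matters or whether the loss of the ring group is enough, a question that bromo, chloro, an amine or a short chain such as ethyl on the same carbon could help to answer. Among these compounds, they also leave open how methoxy in place of methyl would read alongside iodo, as the only methoxy compound here, compound 1, carries 1-benzofuran-2-yl.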